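A few compounds are considered here, and "the series" means these few. Any claim that something is new, unique, unknown or untested is made for them only; others in the source may bear on it.

Compound 1 `CCOC(=O)C1=Cc2ccccc2OC1(OCc1cn(-c2ccc(C)cc2)nn1)C(F)(F)F` is tested in a functional assay on MCF7 cells (Homo sapiens) for inhibition, read by MTT assay, with a stated time of 24 h (on this read-out higher numbers stand for weaker inhibition and lower numbers for stronger inhibition), where compound 1 gives 26700 nM. Within the data shown here, that is the only plain number in this set. Compound 2 `O=C(O)C1=Cc2ccccc2OC1(OCc1cc(-c2ccc([N+](=O)[O-])cc2)no1)C(F)(F)F` reaches only > 150000 nM in this assay, which is a limit of the assay rather than a number. So compound 1 stands as the single measured value, beside (the limit of > 150000 nM in this assay, at which 1 of the 2 values shown sits).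

Compound 3 `CCOC(=O)C1=Cc2ccccc2OC1(OCc1cn(CC(=O)Nc2ccc(I)cc2Cl)nn1)C(F)(F)F` keeps the core of compound 1 and changes one group: ((2-chloro-4-iodophenyl)carbamoyl)methyl in place of 4-methylphenyl on an aromatic nitrogen. Among the measured compounds shown here, no measured pair with a single change is available, so the size of this step cannot be read from earlier data. Compound 3 is expected to sit within the usual scatter of compound 1, with the step from compound 1 to compound 3 estimated as a 1.2-fold lower number from compound 1 to compound 3 (0.08 log units; within the scatter) in this assay. Compound 3 is therefore estimated at 22000 nM, between 6000 nM and 90000 nM.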

Compound 3, half-maximal inhibitory concentration: 28100 nM
Compound 3: the middle estimate sits 1.3-fold (0.11 log units) below what was measured, and the stated range covers the measured number.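

Putting ((2-chloro-4-iodophenyl)carbamoyl)methyl in place of 4-methylphenyl on the aromatic nitrogen gives a 1.1-fold higher number from compound 1 to compound 3 (0.02 log units; within the scatter) in this assay, so compound 1 and compound 3 cannot be told apart on this read-out. Among these compounds, this is the first readable step at this position, and it shows that the number can hold while the group grows to more heavy atoms and gains an amide, a chlorine and an iodine. No measurement shown here bears on why the number holds across this change.

Among the compounds shown here, compound 2 differs from both compounds in more than one place, and no step to it can be read. From the compounds shown here alone, whether a small methyl or an aminoethyl chain on the same nitrogen would also leave the number in place remains open.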